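A few compounds are considered here, and "the series" means these few. Any claim that something is new, unique, unknown or untested is made for them only; others in the source may bear on it.

Working notes on the series. The shared core appears in compound 1 `Cc1ccc2nc(Cl)c(/C=C3\C(=O)N(c4c(Cl)cccc4Cl)c4ccccc43)cc2c1`, for which a functional assay on MIA PaCa-2 cells (Homo sapiens) for cytotoxicity, read by MTT assay, with a stated time of 72 h (a lower number here means that less compound is needed, a higher number that more compound is needed for the effect), gave "not determined" (no result reported). Compound 2 `O=C1/C(=C\c2cccc(Oc3ccccc3)c2)c2ccccc2N1c1c(Cl)cccc1Cl` sits at the edge of this assay: the value of > 100 ug/mL for compound 2 is a limit, not a number, as the limit of > 100 ug/mL in this assay, at which 1 of the 2 values shown sits, records. Compound 3 `O=C1/C(=C\c2cccc(Cl)c2)c2ccccc2N1c1c(Cl)cccc1Cl` carries chloro in place of phenoxy on an aromatic carbon, chloro in place of phenoxy on an aromatic carbon. Among the compounds with values here, no measured step covers this change, so in this assay no step beyond the scatter is expected in either direction. Compound 3 is expected to give 100 ug/mL, in the range 40 ug/mL to 250 ug/mL, an estimated step of a number no higher from compound 2 to compound 3 (the limit leaves the size open).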

Compound 3, concentration for half-maximal effect: 5 ug/mL
Compound 3: the middle estimate sits 20-fold (1.30 log units) above what was measured, and the stated range ends above it.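

Within the data shown here, on the six-membered aromatic ring of carbon only, this position clearly affects the result: in this assay, chloro in place of phenoxy gives an at least 20-fold lower number from compound 2 to compound 3 (1.30 log units; beyond the scatter), the only step that can be read. Compound 2 gives a limit and not a number, so this step has no upper size: the limit of > 100 ug/mL in this assay, at which 1 of the 3 values shown sits. Whether the lower number follows from chloro itself or from the loss of phenoxy stays open, and the compounds shown give no cause for it. A methoxy group, an amine or a carboxylic acid on this carbon would separate these two readings.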